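A methylsulfonyl ester takes the place of the butyl chain

The source may report more compounds than this note shows. Statements on the series, on what has been measured and on what is new or still open speak of the compounds shown alone.

The series shares the core seen in compound 1 `Oc1ccc2nc(-c3ccccc3)cc(O)c2c1`, which in a functional assay on KB cells (Homo sapiens) for cytotoxicity (on this read-out higher numbers stand for an effect only at larger amounts of compound and lower numbers for an effect already at smaller amounts), gives 0.41 ug/mL. Compound 2 `CC(C)COc1cc(-c2ccccc2)nc2ccccc12` is the isobutyl ether; in this assay compound 2 reaches only a limit, > 4 ug/mL. Compound 3 `CCCCOc1cc(-c2ccccc2)nc2ccccc12`, the butyl ether, is measured at 3.8 ug/mL in this assay, the highest of the two numbers recorded, and compound 1 sits well below it. Among the compounds with values here, the one measured step, an at least 1.0-fold lower number from compound 2 to compound 3 (0.02 log units; that floor lies within the scatter), stays within the scatter.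

Compound 4 `CS(=O)(=O)Oc1cc(-c2ccccc2)nc2ccccc12` differs from compound 3 by methylsulfonyl in place of butyl on an oxygen on an aromatic ring. Within the data shown here, no measured step changes this group in the same way; the only step that touches this oxygen, the chain change from compound 2 to compound 3, moved the number hardly at all, and the limit of > 4 ug/mL in this assay, at which 1 of the 3 values shown sits, shows that one ether already sits at the edge of this assay. Compound 3 therefore serves as the anchor, and the expected step of a 1.1-fold lower number from compound 3 to compound 4 (0.04 log units; within the scatter) is small, with no direction claimed beyond the scatter. Compound 4 is estimated at 3.5 ug/mL, within an expected range from 1.2 ug/mL to 10 ug/mL.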

Compound 4, half-maximal effective concentration: 2.8 ug/mL
The estimate for compound 4 lay 1.3-fold (0.10 log units) above the measured number, and the stated range covers the measured number.
By their numbers in this assay, from the lowest: compound 1; then compounds 4 and 3 (each within the scatter of the next). At a limit, above all of these: compound 2.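

In this assay, replacing butyl with methylsulfonyl on this oxygen changes the kind of group and not only the shape of a chain, as the earlier ethers did: methylsulfonyl brings hydrogen-bond acceptors and double bonds outside aromatic rings, yet the result is a 1.4-fold lower number from compound 3 to compound 4 (0.13 log units; within the scatter). The comparison with the isobutyl ether reads an at least 1.4-fold lower number from compound 2 to compound 4 (0.15 log units; that floor lies within the scatter), so this change also shows no effect beyond the scatter. Compound 2 stands at a limit and not at a number: the limit of > 4 ug/mL in this assay, at which 1 of the 4 values shown sits.

Compound 1, at 0.41 ug/mL, differs from the other compounds in more than one place, so its value cannot be tied to the group on this oxygen alone. The compounds shown leave open whether an acetyl group or a longer chain ending in an amine at this position would move the number beyond the scatter.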